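Replacing Fluoro with Hydrogen on Compound 1

A few compounds are considered here, and "the series" means these few. Any claim that something is new, unique, unknown or untested is made for them only; others in the source may bear on it.

Compound 1 `Cc1cccc2c(-c3ccc4cccc(F)c4n3)c[nH]c12`: 0.983 h
Compound 2 `Cc1cccc2c(-c3ccc4c(O)cccc4n3)c[nH]c12`: 0.283 h
Compound 3 `Fc1cc2c(-c3ccc4c(C(F)(F)F)cccc4n3)c[nH]c2c(F)c1F`: 1.12 h

All three values come from an ADME assay on microsomes from liver (Homo sapiens) for metabolic stability, using NADPH, with a stated time of 40 min, tested at 2 uM; a higher number here means that the compound lasts longer, a lower number that the compound disappears faster. Compound 1 at 0.983 h lies within the scatter of compound 3 at 1.12 h. Compound 2 gives 0.283 h, and the gap between this number and that of compound 1 lies beyond the scatter.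

Compound 4 `Cc1cccc2c(-c3ccc4ccccc4n3)c[nH]c12` has not yet been measured in this assay. It differs from compound 1 by hydrogen in place of fluoro on an aromatic carbon, with hydrogen in place of fluoro on an aromatic carbon. Within the data shown here, no pair of measured compounds differs in one place only, so the data give no direct size for such a change. A small downward step, within the scatter, is expected.

The estimated 1.3-fold lower number from compound 1 to compound 4 (0.12 log units; within the scatter) reflects this expectation.

Compound 4 is expected at 0.75 h, with an estimated range from 0.35 h to 1.5 h.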

Compound 4, half-life: 0.35 h
For compound 4 the middle estimate is 2.1-fold (0.33 log units) above the measured one, and the stated range covers the measured number.
By their numbers in this assay, from the lowest: compounds 2 and 4 (each within the scatter of the next); then compounds 1 and 3 (each within the scatter of the next).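

In this assay hydrogen in place of fluoro on this aromatic carbon gives a 2.8-fold lower number from compound 1 to compound 4 (0.45 log units; beyond the scatter) and so puts a first direct size on a change at this position. Hydrogen in place of hydroxy on an aromatic carbon gives a 1.2-fold higher number from compound 2 to compound 4 (0.09 log units; within the scatter) and stays within the scatter. Of these two replacements, only the loss of fluoro gives a step beyond the scatter.

Going by these compounds, whether chloro or methoxy on the same carbon would match fluoro or hydrogen remains open. The compounds shown offer no measurement that explains the step.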